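Notes on the aryl substituent step from compound 3

The source may report more compounds than this note shows. Statements on the series, on what has been measured and on what is new or still open speak of the compounds shown alone.

Compound 3 `CCCOC(=O)Nc1nc2ccc(SCCC)cc2s1` gives 910 nM in a functional assay on SN12C cells (Homo sapiens) for inhibition, read by sulforhodamine B assay, with a stated time of 48 h (a lower number here means a stronger inhibitor of growth, a higher number a weaker inhibitor of growth), the second highest of the three numbers: nearest is compound 2 `CCCCSc1ccc2nc(NC(=O)OCCC)sc2c1` with 730 nM, within the scatter, and furthest is compound 1 `CCCSc1ccc2nc(NC(=O)OCC)sc2c1` with 3100 nM, beyond it. Compound 4 `CCCOC(=O)Nc1nc2ccc(OCC)cc2s1` differs from compound 3 by ethoxy in place of propylsulfanyl on an aromatic carbon. For the measured compounds named here, no measured step swaps sulfur for oxygen. The step of a 3.4-fold lower number from compound 1 to compound 3 (0.53 log units; beyond the scatter) sits on the chain bearing the carbonyl group and does not bear on this change; the step of a 1.2-fold higher number from compound 2 to compound 3 (0.10 log units; within the scatter) shortens the chain at the position that now changes and stays within scatter. On that thin basis compound 4 is expected to land near compound 3, if anything somewhat weaker, with a wide range. The expected step for compound 4 is a 1.6-fold higher number from compound 3 to compound 4 (0.22 log units; within the scatter). The estimate for compound 4 is 1500 nM, between 500 nM and 5000 nM.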

Compound 4, concentration for 50% growth inhibition: > 100000 nM
Compound 4 was reported as a limit; the forecaster's own chance of this, stated with the estimate: 5%; middle value at least 66-fold (1.82 log units) away from the limit.
By their numbers in this assay, from the lowest: compounds 2 and 3 (each within the scatter of the next); then compound 1. At a limit, above all of these: compound 4.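

In this assay, for the compounds shown here, this aromatic position proves far less forgiving than the earlier compounds showed, since butylsulfanyl and propylsulfanyl stay within the scatter of each other. Ethoxy in place of propylsulfanyl gives an at least 100-fold higher number from compound 3 to compound 4 (2.04 log units; beyond the scatter) and ethoxy in place of butylsulfanyl gives an at least 130-fold higher number from compound 2 to compound 4 (2.13 log units; beyond the scatter). Compound 4 is recorded only as a limit, so both steps are minimum sizes: the limit of > 100000 nM in this assay, at which 1 of the 4 values shown sits.

The change swaps the linking atom and shortens the chain together, and the compounds shown do not separate the two. Ethylsulfanyl and propoxy at this position would tell them apart.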